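Pyridin-2-yl for Phenyl: A Small Step Expected

This account rests on a few compounds, and the source may have more. Where it says the series, first, only, none or still open, it means among the compounds named here.

In a functional assay on HO8910 cells (Homo sapiens) for inhibition, read by MTT assay, with a stated time of 24 h, tested at 1 ug/mL (a higher number here means more inhibition of growth at the concentration tested, a lower number less inhibition of growth), compound 1 (`O=C(CCCCC1CCSS1)Nc1ccccn1`) is reported as "not active" (no number reported) with no figure attached. Among the compounds with values here, compound 2 (`O=C(CCCCC(S)CCS)Nc1ccccc1`) gives 6.38% and so holds the only number available, which means it cannot yet be ranked against a second measured value.

Compound 3 (`O=C(CCCCC(S)CCS)Nc1ccccn1`) has not been tested yet. It differs from compound 2 in a single place (pyridin-2-yl in place of phenyl on an amide-type nitrogen), with pyridin-2-yl in place of phenyl on an amide-type nitrogen. Swapping one ring for another of the same size is a modest edit, but no measured pair here shows what this particular change does. For that reason, no step beyond the usual scatter is expected in this assay, and neither direction is favoured. Within the data shown here, the only numerical anchor is compound 2 at 6.38% in a single measurement. The estimated step (a number 0.6 percentage points higher from compound 2 to compound 3 (within the scatter)) is therefore expected to be small. A report without a number also remains possible. The expected result for compound 3 is about 7% (estimated range 0% to 18%).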

Compound 3, percent growth inhibition at one concentration: "not active" (no number reported)
The entry for compound 3 holds no number, and the estimate cannot be compared.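

In this assay, within the data shown here, compound 3 gives "not active" (no number reported) and compound 2 gives 6.38%, so no step between compound 2 and compound 3 can be read. Nothing shown here offers an explanation for this result. As far as these compounds go, how far pyridin-2-yl in place of phenyl on an amide-type nitrogen shifts growth inhibition stays open.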